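The compounds below may be only part of what the source reports. "The series", "measured", "known", "first", "only" and "open" are said of these compounds alone.

Compound 1 `Cc1ccccc1C(=O)Nc1sc2c(c1C(N)=O)CCN(C(=S)Nc1ccccc1Cl)C2`: 20900 nM
Compound 2 `Cc1ccccc1NC(=S)N1CCc2c(sc(NC(=O)c3ccccc3Br)c2C(N)=O)C1`: > 50000 nM
Compound 3 `Cc1ccccc1C(=O)Nc1sc2c(c1C(N)=O)CCN(C(=S)Nc1ccccc1Br)C2`: 45200 nM

Of the compounds shown here, three built on one shared core have been tested in a functional assay on HL-60 cells (Homo sapiens) for antiproliferative activity, with a stated time of 24 h; on this read-out lower numbers stand for stronger inhibition and higher numbers for weaker inhibition. Compound 1 gives 20900 nM. Going by the values given here, compound 3 gives 45200 nM, the higher of the two numbers known. For compound 2 the result is only a limit of this assay, > 50000 nM, so no number exists for it. Compound 1 and compound 3 differ in a single place, and the step between them, a 2.2-fold higher number from compound 1 to compound 3 (0.33 log units; beyond the scatter), is modest yet beyond the usual scatter of repeat measurements.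

Compound 4 `Cc1ccccc1NC(=S)N1CCc2c(sc(NC(=O)c3ccccc3C)c2C(N)=O)C1` has not yet been measured in this assay. It differs from compound 3 in one place: methyl in place of bromo on an aromatic carbon. Among the compounds with values here, the only measured step that touches the same position is the one from compound 1 to compound 3, where one halogen replaced another and the number rose modestly. The move from bromo to methyl has no measured counterpart among these compounds, so the expectation leans on the general size of that one step and on the chloro value of compound 1 as a guide.

Compound 4 is therefore expected to give roughly 25000 nM, within a range from 10000 nM to 60000 nM. This expected result would mean a step of a 1.8-fold lower number from compound 3 to compound 4 (0.26 log units; within the scatter), a modest lowering that may or may not clear the scatter.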

Compound 4, half-maximal inhibitory concentration: > 50000 nM
Compound 4: no number, only a limit (the forecaster's own chance of this, stated with the estimate: 20%); middle value at least 2.0-fold (0.30 log units) from the limit.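

In this assay compound 4 gives only a limit, > 50000 nM, and it does not stand alone there: the limit of > 50000 nM in this assay, at which 2 of the 4 values shown sit. The earlier compounds compared only two halogens at this place on the aromatic ring, and now a carbon group can be set against them: methyl in place of chloro gives an at least 2.3-fold higher number from compound 1 to compound 4 (0.37 log units; beyond the scatter), a change that clears the scatter, so among these three groups the number stays lower with chloro than with either bromo or methyl. Methyl in place of bromo gives an at least 1.1-fold higher number from compound 3 to compound 4 (0.04 log units; that floor lies within the scatter), and since that floor lies within the scatter these two compounds cannot be put in order, while the step from compound 2, which joins two limits, cannot be read.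

Going by these compounds, how far compound 4 really lies past its limit remains unknown, so the size of the methyl change is only bounded on one side. Also open, on these data alone, is whether a smaller halogen such as fluoro, a plain hydrogen, or a methoxy or amine group at this same place would bring the number down further, or whether the trend seen here holds only for these three groups.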